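The source may hold more compounds than are shown below. What is called first, only, known or untested is meant among the compounds shown, and "the series" means these compounds.

Measured so far:
compound 1, `COc1ccccc1N1CCN(CCCNc2nc(C)cc(C)c2C(N)=O)CC1`, 39.8 nM;
compound 2, `COc1ccccc1N1CCN(CCCSc2ccccc2C(=O)N(C)C)CC1`, 12.6 nM;
compound 3, `CN(C)C(=O)c1cccnc1NCCCN1CCN(c2ccccc2O)CC1`, 63.1 nM.

All three values come from a functional assay on aorta for antagonist activity at Alpha-1D adrenergic receptor (Rattus norvegicus); on this read-out lower numbers stand for tighter binding and higher numbers for weaker binding. Among them compound 3 gives the highest number. Its nearest neighbour is compound 1, whose number is lower by a margin that stays within the usual scatter, so the two cannot be told apart on this read-out. Compound 2 stands furthest from compound 3, with a number lower by a margin that lies beyond the scatter.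

Compound 4, `CCCc1ccccc1N1CCN(CCCNc2ncccc2C(=O)N(C)C)CC1`, has not yet been measured in this assay. It differs from compound 3 in one place: propyl in place of hydroxy on an aromatic carbon. Among the compounds with values here, no step between measured compounds matches this change, so no direct precedent exists. The account expects that the step from compound 3 to compound 4 in this assay, a 1.6-fold lower number from compound 3 to compound 4 (0.20 log units; within the scatter), will be small and toward a lower number, since compound 1, which carries a group other than hydroxy at the same place, gives 39.8 nM, and compound 2, which also carries a group other than hydroxy there, gives 12.6 nM. For compound 4 the expected value in this assay is 40 nM, within a range from 12 nM to 130 nM.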

Compound 4, dissociation constant: 31.6 nM
The estimate for compound 4 lay 1.3-fold (0.10 log units) above the measured number; the measured number falls inside the stated range.
By their numbers in this assay, from the lowest: compound 2; then compounds 4, 1 and 3 (each within the scatter of the next).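

In this assay, within the data shown here, the step of a 2.0-fold lower number from compound 3 to compound 4 (0.30 log units; within the scatter) gives the first direct comparison at this place on the ring, since compounds 1 and 2 differ from compound 3 in more than one place. Propyl, with more heavy atoms and no hydrogen-bond donor or acceptor, can therefore stand in place of hydroxy, ortho to a large group, without a difference that this read-out can resolve. Nothing shown bears on why the two compounds read alike.

This single step cannot show whether the hydrogen-bond donor or acceptor of hydroxy matters at this place, or whether the size of the group does. An amine, a carboxylic acid or a longer chain such as hexyl at the same place remains an open case, and these compounds do not say how any of them would read.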